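The source may report more compounds than this note shows. Statements on the series, on what has been measured and on what is new or still open speak of the compounds shown alone.

Measured in a functional assay on SGC-7901 cells (Homo sapiens) for cytotoxicity, read by MTT assay, with a stated time of 48 h (on this read-out higher numbers stand for weaker inhibition and lower numbers for stronger inhibition), so far:
compound 1 `Cc1ncc([N+](=O)[O-])n1CCSc1nnc(-c2ccc(N)cc2)o1` — 31700 nM
compound 2 `Cc1ncc([N+](=O)[O-])n1CCSc1nnc(-c2ccc(N(C)C)cc2)o1` — 32800 nM

In this assay compound 1 gives 31700 nM, the smaller of the two numbers shown, though its nearest neighbour, compound 2 at 32800 nM, sits so close that the step of a 1.0-fold higher number from compound 1 to compound 2 (0.01 log units; within the scatter) falls within the scatter and the two cannot be ranked. Compound 3 `Cc1ncc([N+](=O)[O-])n1CCSc1nnc(-c2cnccc2N)o1` differs from compound 1 in one place: 4-aminopyridin-3-yl in place of 4-aminophenyl on an aromatic carbon. Going by the values given here, the single measured step, a 1.0-fold higher number from compound 1 to compound 2 (0.01 log units; within the scatter), concerns the substituent on the six-membered ring rather than the ring itself, so it bears on the present change only loosely; what it does show is that altering this end of the molecule left this assay essentially unmoved. Among the compounds with values here, no measured pair exchanges the six-membered ring for one with a hetero atom, so the effect of that exchange is unknown. The step of a 1.1-fold higher number from compound 1 to compound 3 (0.03 log units; within the scatter) is therefore expected to remain within the scatter, in no clear direction. For compound 3 the estimate in this assay is 34000 nM, with a range from 14000 nM to 85000 nM.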

Compound 3, half-maximal inhibitory concentration: 34500 nM
Compound 3: the middle estimate sits 1.0-fold (0.01 log units) below what was measured, and the stated range covers the measured number.
By their numbers in this assay, from the lowest: compounds 1, 2 and 3 (each within the scatter of the next).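

In this assay the change from 4-aminophenyl to 4-aminopyridin-3-yl gives a 1.1-fold higher number from compound 1 to compound 3 (0.04 log units; within the scatter), so compound 1 and compound 3 cannot be told apart. The earlier pair, compound 1 and compound 2, varied only the substituent on the six-membered ring, whereas this result shows that a hetero atom in the ring itself, with 2 hydrogen-bond acceptors in the group instead of 1, also produces no step beyond the scatter at this position on the five-membered aromatic ring. Nothing available here accounts for this outcome.

All three compounds therefore sit within the scatter of one another, and they leave open whether any group at this position can move the number beyond it, for example a carboxylic acid or a nitrile in place of the amino group on the six-membered ring. They also leave open whether a longer chain in the link of the shared core would matter more in this assay than the changes to the aromatic end have so far.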